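The source may report more compounds than this note shows. Statements on the series, on what has been measured and on what is new or still open speak of the compounds shown alone.

Going by the values given here, only two compounds sharing a core have been measured so far in a physicochemical assay for solubility, with a stated time of 24 h, tested at 30 mg/mL (on this read-out higher numbers stand for higher solubility and lower numbers for lower solubility), for this series. Compound 1 (`CN(C)c1ccc(Nc2c(NCCCCCC(=O)NO)c(=O)c2=O)cc1`) gives 1400000 nM and compound 2 (`O=C(CCCCCNc1c(Nc2ccc(C(F)(F)F)cc2)c(=O)c1=O)NO`) gives 4700000 nM on this scale, which places compound 2 as the higher of the pair. Compound 3 (`CC(CCCCC(=O)NO)Nc1c(Nc2ccc(C(F)(F)F)cc2)c(=O)c1=O`) differs from compound 2 in one place: methyl in place of hydrogen on a saturated chain carbon bound to a nitrogen on an aromatic ring and a saturated chain carbon describes the change, methyl in place of hydrogen on a saturated chain carbon bound to a nitrogen on an aromatic ring and a saturated chain carbon. Among the compounds with values here, the only measured step, a 3.4-fold higher number from compound 1 to compound 2 (0.53 log units; beyond the scatter), is modest but beyond the scatter. That step is trifluoromethyl in place of dimethylamino on an aromatic carbon, so it gives only a rough sense of scale. Within the data shown here, no measured step involves the saturated chain, and the direction of any effect there is unknown. In this assay no shift beyond the scatter is therefore expected. The expected change is a 1.1-fold higher number from compound 2 to compound 3 (0.03 log units; within the scatter) in this estimate. For compound 3 the estimated value is 5000000 nM, with an expected range from 2000000 nM to 12000000 nM in repeated measurements.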

Compound 3, solubility: 20000000 nM
Beside the measured number, compound 3's estimate is 4.0-fold (0.60 log units) below it, and the stated range ends below it.
By their numbers in this assay, from the lowest: compound 1; then compound 2; then compound 3.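

In this assay, the saturated chain carbon bound to a nitrogen on an aromatic ring and a saturated chain carbon proves to be a place where the read-out responds: methyl in place of hydrogen gives a 4.3-fold higher number from compound 2 to compound 3 (0.63 log units; beyond the scatter). Going by these compounds alone, the only earlier step lay on an aromatic carbon, a 3.4-fold higher number from compound 1 to compound 2 (0.53 log units; beyond the scatter), so this is the first measured sign that a change on the chain can also move the number beyond the scatter, and here it does so with only 1 heavy atom entering, no ring and no net charge. No measured evidence here explains this step.

The compounds shown leave open whether the rise is particular to methyl or would also appear with another group at this carbon, such as an ethyl, a hydroxymethyl or an amine. Within the data shown here, they also leave open whether the same methyl would give a similar step on the dimethylamino compound, compound 1, since the only example of this change carries trifluoromethyl on the aromatic carbon.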